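Adding an amino group to compound 2

The compounds below may be only part of what the source reports. "The series", "measured", "known", "first", "only" and "open" are said of these compounds alone.

Values in a functional assay on the whole organism with Mus musculus as the target; a higher number here means that more compound is needed for the effect, a lower number that less compound is needed:
- compound 1 `COc1cc2c(cc1OC)C(c1ccc([N+](=O)[O-])cc1)=NN=C(S)C2`: 93.4 umol/kg
- compound 2 `COc1cc2c(cc1OC)C(c1ccccc1)=NNC(=O)C2`: 33.9 umol/kg
- compound 3 `COc1cc2c(cc1OC)C(c1ccc([N+](=O)[O-])cc1)=NNC(=O)C2`: > 120 umol/kg (a limit)

Among the measured compounds shown here, only two of these values are true numbers, and the lower belongs to compound 2. Compound 2 gives 33.9 umol/kg, while its nearest neighbour, compound 1, gives 93.4 umol/kg, a gap beyond the usual scatter. For compound 3, > 120 umol/kg is a limit of the assay and not a number.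

Compound 4 `COc1cc2c(cc1OC)C(c1cccc(N)c1)=NNC(=O)C2` differs from compound 2 by one change, amino in place of hydrogen on an aromatic carbon, meta to a large group. For the measured compounds named here, the only measured step that bears on this is an at least 3.5-fold higher number from compound 2 to compound 3 (0.54 log units; beyond the scatter), which lies beyond the scatter. Going by the values given here, that step places nitro on an aromatic carbon, however, and no measured step involves amino. It therefore gives only weak guidance, so no step beyond the scatter is expected in this assay, though a rise remains possible. The expected change is a 1.2-fold higher number from compound 2 to compound 4 (0.07 log units; within the scatter). For compound 4, the estimated value is 40 umol/kg, with an expected range from 14 umol/kg to 115 umol/kg.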

Compound 4, dose for half-maximal effect: 19.3 umol/kg
Compound 4: middle estimate off by 2.1-fold (0.32 log units), on the high side, within the range that was stated.
By their numbers in this assay, from the lowest: compounds 4 and 2 (each within the scatter of the next); then compound 1. At a limit, above all of these: compound 3.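

In this assay, amino on this carbon of the phenyl ring, meta to a large group, gives a 1.8-fold lower number from compound 2 to compound 4 (0.24 log units; within the scatter), so this change brings no measurable loss and compound 4 cannot be told apart from compound 2. The nitro step, by contrast, was an at least 3.5-fold higher number from compound 2 to compound 3 (0.54 log units; beyond the scatter), so not every group added to this ring raises the number beyond the scatter. Compound 3 stands at a limit and not at a true number: the limit of > 120 umol/kg in this assay, at which 1 of the 4 values shown sits.

From the compounds shown here alone, whether a hydroxyl, a methoxy or a longer chain on this same carbon would also stay within the scatter remains open, as does the effect of an amino group on another carbon of the ring. With amino the only group shown at this carbon, no trend across groups can be drawn.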